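A Repeated Swap, Tested on a Second Core

The compounds below may be only part of what the source reports. "The series", "measured", "known", "first", "only" and "open" are said of these compounds alone.

Measured so far:
compound 1, `C#Cc1cn([C@@H]2O[C@H](CO)[C@@H](O)[C@H]2O)c2ncnc(C)c12` — 14700 nM
compound 2, `Cc1ncnc2c1c(-c1ccsc1)cn2[C@@H]1O[C@H](CO)[C@@H](O)[C@H]1O` — 14300 nM
compound 3, `C#Cc1cn([C@@H]2O[C@H](CO)[C@@H](O)[C@H]2O)c2ncnc(SC)c12` — 110 nM

All three compounds were tested in a functional assay on HeLa S3 cells (Homo sapiens) for antiproliferative activity, read by XTT assay, with a stated time of 72 h; a higher number here means a weaker inhibitor, a lower number a stronger inhibitor. Compound 1 and compound 2 share a core and differ at one place: thiophen-3-yl in place of ethynyl on an aromatic carbon. That exchange gave a 1.0-fold lower number from compound 1 to compound 2 (0.01 log units; within the scatter), so the two values show no difference that can be read.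

Compound 3 carries a different core. Its core differs from that of compound 1 at one place: methylsulfanyl in place of methyl on an aromatic carbon. This exchange produced a 130-fold lower number from compound 1 to compound 3 (2.13 log units; beyond the scatter), a large step, and compound 3 stands lowest of the three measured values, beyond the scatter from both others.

Compound 4, `CSc1ncnc2c1c(-c1ccsc1)cn2[C@@H]1O[C@H](CO)[C@@H](O)[C@H]1O`, has not yet been measured in this assay. It stands to compound 3 as compound 2 stands to compound 1: thiophen-3-yl in place of ethynyl on an aromatic carbon. The place description around the exchanged group is the same word for word in both pairs, so this is the same change, made on the second core.

Among the measured compounds shown here, the one earlier instance of this change, between compound 1 and compound 2, moved the number by almost nothing. Resting on that, the step from compound 3 to compound 4 is expected to be no change at the digits printed from compound 3 to compound 4 (within the scatter), within the scatter. For the measured compounds named here, compound 4 is therefore estimated at 110 nM, with a range from 40 nM to 320 nM to allow for the scatter of repeated measurements and for only a single earlier example of the change.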

Compound 4, half-maximal inhibitory concentration: > 20000 nM
Compound 4: no number, only a limit; the forecaster's own chance of this, stated with the estimate: 2%; middle value at least 180-fold (2.25 log units) away from the limit.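

In this assay compound 4 gives > 20000 nM, which is a limit of the assay and not a number. Thiophen-3-yl in place of ethynyl on an aromatic carbon gave an at least 180-fold higher number from compound 3 to compound 4 (2.25 log units; beyond the scatter), so this change, silent on the core of compound 1, did not carry over to the core of compound 3: the same change on two cores in this assay, a 1.0-fold lower number (0.01 log units; within the scatter) from compound 1 to compound 2 and an at least 180-fold higher number (2.25 log units; beyond the scatter) from compound 3 to compound 4, at least 180-fold (2.27 log units) apart, beyond the scatter of two such steps Read the other way, methylsulfanyl in place of methyl on an aromatic carbon gave an at least 1.3-fold higher number from compound 2 to compound 4 (0.14 log units; that floor lies within the scatter), so in these four compounds the large drop in the number appears only with ethynyl present; this shows that the two changes do not add independently here, but a single set of four compounds does not show why, or how large the steps to compound 4 really are: the same change on two cores in this assay, a 130-fold lower number (2.13 log units; beyond the scatter) from compound 1 to compound 3 and an at least 1.3-fold higher number (0.14 log units; that floor lies within the scatter) from compound 2 to compound 4, at least 180-fold (2.27 log units) apart, beyond the scatter of two such steps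

The compounds shown leave open whether the low number requires ethynyl itself or would also appear with another small group on that aromatic carbon, such as a nitrile or a chlorine atom. They also leave open whether an amine or a methoxy group in place of methylsulfanyl would depend on the ethynyl group in the same way.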